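Aryl amide variation on the shared core

The compounds below may be only part of what the source reports. "The series", "measured", "known", "first", "only" and "open" are said of these compounds alone.

Compound 1 `CCCOC(=O)c1ccc(NC(=O)c2cccc(-c3cc(C(=O)Nc4ccncc4F)ccc3CN)c2)cc1`, compound 2 `COC(=O)c1cccc(NC(=O)c2cccc(-c3cc(C(=O)Nc4ccncc4F)ccc3CN)c2)c1F` and compound 3 `NCc1ccc(C(=O)Nc2ccncc2F)cc1-c1cccc(C(=O)Nc2cccc(CC(=O)O)c2)c1` share one core and differ only in the aryl group on an amide-type nitrogen. In an assay on cells for inhibition of Rho-associated protein kinase 2 (Homo sapiens), read by radiometric assay and 33P incorporation, in the presence of a further agent that is not named here (on this read-out lower numbers stand for stronger inhibition and higher numbers for weaker inhibition), compound 1 gives a limit of the assay, < 1 nM (the limit of < 1 nM in this assay, at which 1 of the 3 values shown sits). In this assay compound 2 gives 1.2 nM and compound 3 gives 1.5 nM. Compound 3 thus stands at the highest of the two numbers, the gap being a 1.3-fold higher number from compound 2 to compound 3 (0.10 log units; within the scatter). Compound 4 `NCc1ccc(C(=O)Nc2ccncc2F)cc1-c1cccc(C(=O)Nc2cccc(C(=O)O)c2F)c1` follows compound 3 with 3-carboxy-2-fluorophenyl in place of 3-(carboxymethyl)phenyl on an amide-type nitrogen. The steps at this position, an at least 1.2-fold higher number from compound 1 to compound 2 (0.07 log units; that floor lies within the scatter) and an at least 1.5-fold higher number from compound 1 to compound 3 (0.17 log units; that floor lies within the scatter), stay within the scatter, so no step beyond the scatter is expected in this assay. Compound 4 is therefore expected to give 1.3 nM, from 0.5 nM to 3.5 nM. The expected step of a 1.2-fold lower number from compound 3 to compound 4 (0.06 log units; within the scatter) lies within the scatter.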

Compound 4, half-maximal inhibitory concentration: 3.5 nM
For compound 4 the middle estimate is 2.7-fold (0.43 log units) below the measured one, within the range that was stated.
By their numbers in this assay, from the lowest: compounds 2 and 3 (each within the scatter of the next); then compound 4. At a limit, below all of these: compound 1.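

In this assay, among the compounds shown here, this position now shows steps beyond the scatter, which the earlier compounds did not: 3-carboxy-2-fluorophenyl in place of 3-(carboxymethyl)phenyl gives a 2.3-fold higher number from compound 3 to compound 4 (0.37 log units; beyond the scatter), and hydrogen in place of methyl on the oxygen next to a carbonyl group gives a 2.9-fold higher number from compound 2 to compound 4 (0.46 log units; beyond the scatter). Both steps are modest. The step of an at least 3.5-fold higher number from compound 1 to compound 4 (0.54 log units; beyond the scatter) is only a floor, since compound 1 stands at a limit: the limit of < 1 nM in this assay, at which 1 of the 4 values shown sits.

From the compounds shown here alone, the change between compound 3 and compound 4 alters both the fluorine and the acid chain, so their separate contributions remain open. Going by these compounds, a sulfonamide or an amine in place of the carboxylic acid also remains open.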